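A few compounds are considered here, and "the series" means these few. Any claim that something is new, unique, unknown or untested is made for them only; others in the source may bear on it.

Series values in a physicochemical assay for lipophilicity; on this read-out higher numbers stand for higher lipophilicity and lower numbers for lower lipophilicity:
- compound 1 `Cc1nc(-c2cc(C(F)(F)F)ccc2[C@H]2CCOc3cc(S(=O)(=O)Nc4ccncn4)ccc32)co1`: "not determined" (no result reported)
- compound 2 `Cc1ccc(-c2cc(C(F)(F)F)ccc2[C@H]2CCOc3cc(S(=O)(=O)Nc4ncc(F)cn4)ccc32)cn1`: 2.5
- compound 3 `Cc1ccc(-c2cc(C(F)(F)F)ccc2[C@H]2CCOc3cc(S(=O)(=O)Nc4ccncn4)ccc32)cn1`: 3

In this assay, compound 3 stands highest of the two available numbers, and compound 1 has no number. Compound 4 `O=S(=O)(Nc1ccncn1)c1ccc2c(c1)OCC[C@@H]2c1ccc(C(F)(F)F)cc1-c1ccc(F)cn1` carries 5-fluoropyridin-2-yl in place of 6-methylpyridin-3-yl on an aromatic carbon.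

Going by the values given here, the only measured step, a number 0.50 log units higher from compound 2 to compound 3 (beyond the scatter), is modest and beyond the scatter, but it lies on a sulfonamide nitrogen, so it bears only indirectly. Among the compounds with values here, no step has been measured at the place that changes here. Starting from compound 3 at 3, no shift beyond the scatter is expected. The expected change is a number 0.10 log units higher from compound 3 to compound 4 (within the scatter). For compound 4 the estimated value is 3.1, with an expected range from 2.7 to 3.5.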

Compound 4, distribution coefficient: 3
Estimate against measurement, compound 4: 0.10 log units above, and the stated range covers the measured number.
By their numbers in this assay, from the lowest: compound 2; then compounds 3 and 4 (each within the scatter of the next).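

In this assay, the first step read at this aromatic carbon, ortho to a large group and meta to a trifluoromethyl group, is no change at the digits printed from compound 3 to compound 4 (within the scatter), so the read-out does not separate 5-fluoropyridin-2-yl from 6-methylpyridin-3-yl here. Among the compounds shown, the only step beyond the scatter remains the one on the sulfonamide nitrogen, a number 0.50 log units higher from compound 2 to compound 3 (beyond the scatter). Nothing available accounts for this result.

As far as these compounds go, whether an amine or a carboxylic acid at this aromatic carbon would shift the number stays open. Also open, from the compounds shown here alone, is whether this same exchange reads alike with 5-fluoropyrimidin-2-yl on the sulfonamide nitrogen.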